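Replacing the amino group of compound 3

The source may hold more compounds than are shown below. What is called first, only, known or untested is meant among the compounds shown, and "the series" means these compounds.

In a functional assay on the whole organism (strain Sprague-Dawley) for inhibition, with Rattus norvegicus as the target, with a stated time of 10 min (a higher number here means that more compound is needed for the effect, a lower number that less compound is needed), compound 3 `CCOc1ccc(N)cc1-c1ncc(C(=O)O)c(=O)[nH]1` gives 1.2 mg/kg. Compound 1 `CC(C)Oc1ccccc1-c1ncc(C(=O)O)c(=O)[nH]1`, at 0.8 mg/kg, lies within the scatter of that number, while compound 2 `C=CCOc1ccccc1-c1ncc(C(=O)O)c(=O)[nH]1`, at 0.5 mg/kg, lies beyond the scatter on the lower side. Compound 4 `CCOc1ccc(S(=O)(=O)N(C)C(C)C)cc1-c1ncc(C(=O)O)c(=O)[nH]1` keeps the ethoxy group and the shared core of compound 3 but carries isopropyl(methyl)sulfamoyl in place of amino on an aromatic carbon, para to the ethoxy group: isopropyl(methyl)sulfamoyl in place of amino on an aromatic carbon. Among the compounds with values here, only one measured step is available, a 1.6-fold lower number from compound 1 to compound 2 (0.20 log units; within the scatter). Within the data shown here, it concerns the group on oxygen rather than this position, so it is a weak guide, and no measured compound carries a sulfamoyl group of any kind. With no evidence for a shift in either direction, no step beyond the scatter is expected in this assay, although the uncertainty is wide. The expected step is a 1.3-fold higher number from compound 3 to compound 4 (0.10 log units; within the scatter). For compound 4 the estimated value is 1.5 mg/kg, with an expected range from 0.4 mg/kg to 6 mg/kg.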

Compound 4, dose for 50% inhibition: > 10 mg/kg
Compound 4 gave a limit, no number (the forecaster's own chance of this, stated with the estimate: 10%); middle value at least 6.6-fold (0.82 log units) away from the limit.
By their numbers in this assay, from the lowest: compounds 2, 1 and 3 (each within the scatter of the next, the first and the last beyond it). At a limit, above all of these: compound 4.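

Isopropyl(methyl)sulfamoyl in place of amino, on the aromatic carbon para to the ethoxy group, gives an at least 8.3-fold higher number from compound 3 to compound 4 (0.92 log units; beyond the scatter) in this assay. Unlike the only earlier step, a 1.6-fold lower number from compound 1 to compound 2 (0.20 log units; within the scatter), which concerned the group on oxygen and stayed within the scatter, this one lies beyond it, so this carbon is a place where a change can move the dose needed. The reading for compound 4 is a limit of the assay and not a number, so the full size of the step stays unknown: the limit of > 10 mg/kg in this assay, at which 1 of the 4 values shown sits.

On these data alone, it remains open whether the whole group matters or only part of it, which a sulfamoyl group without the isopropyl and methyl on its nitrogen, or a small group such as methoxy or chlorine, would help to separate. An ethoxy compound with plain hydrogen on this carbon would show what amino itself contributes.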